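The source may report more compounds than this note shows. Statements on the series, on what has been measured and on what is new or still open speak of the compounds shown alone.

Going by the values given here, in a functional assay on MCF7 cells (Homo sapiens) for inhibition, read by MTT assay, with a stated time of 2 days (on this read-out higher numbers stand for weaker inhibition and lower numbers for stronger inhibition), compound 1 `Nc1cccc(/C=C/c2ccccc2)c1` gives 14 ug/mL, the middle of the three numbers measured so far. Compound 2 `Nc1cccc(/C=C/c2ccc(O)cc2)c1` gives the lowest, 6 ug/mL, and compound 3 `COc1ccccc1/C=C/c1cccc(N)c1` gives the highest, 38.7 ug/mL. Compound 4 `COc1cccc(/C=C/c2cccc(N)c2)c1` has not yet been measured. It differs from compound 1 by a single change, methoxy in place of hydrogen on an aromatic carbon.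

Among the compounds with values here, two measured steps bear on this change. The closer guide is a 2.8-fold higher number from compound 1 to compound 3 (0.44 log units; beyond the scatter), which comes from the same swap of hydrogen for methoxy. The group stands at another place in compound 3 than in compound 4, so that guide is only rough. The other is a 2.3-fold lower number from compound 1 to compound 2 (0.37 log units; beyond the scatter), which comes from hydroxy rather than methoxy and runs the opposite way. A somewhat smaller step toward a higher number is therefore expected in this assay, and it may not clear the scatter. The expected step is a 1.7-fold higher number from compound 1 to compound 4 (0.23 log units; within the scatter). For compound 4 the estimated value is 24 ug/mL, with an expected range from 9 ug/mL to 55 ug/mL.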

Compound 4, half-maximal inhibitory concentration: 34 ug/mL
Compound 4: middle estimate off by 1.4-fold (0.15 log units), on the low side; the measured number falls inside the stated range.
By their numbers in this assay, from the lowest: compound 2; then compound 1; then compounds 4 and 3 (each within the scatter of the next).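

In this assay, methoxy in place of hydrogen on an aromatic carbon, meta to a group of 9 heavy atoms, gives a 2.4-fold higher number from compound 1 to compound 4 (0.39 log units; beyond the scatter), so at this place the change clearly moves the number upward. Compound 3, which carries its methoxy at another place, gives 38.7 ug/mL and compound 4 gives 34 ug/mL, values within the scatter of each other, so these two places show no readable difference for this group. No measurement shown here explains why methoxy has this effect.

Hydroxy at this same place remains open, which matters as the step to compound 2 in a 2.3-fold lower number from compound 1 to compound 2 (0.37 log units; beyond the scatter) runs the other way from both methoxy steps. Going by these compounds, how a longer ethoxy group or a carboxylic acid at this place would read in this assay is also open.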